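The source may report more compounds than this note shows. Statements on the series, on what has been measured and on what is new or still open speak of the compounds shown alone.

Measured so far in an ADME assay on MT4 cells (Homo sapiens) for cytotoxicity, read by MTT assay; a higher number here means that more compound is tolerated, a lower number that less compound is tolerated:
compound 1 `Cc1ccc(-n2ccnc2SCC(=O)Nc2ccc(C)cc2Br)cc1`, 80800 nM
compound 2 `O=C(CSc1nccn1-c1cccc2ccccc12)Nc1ccccc1Br`, 30500 nM
compound 3 `O=C(CSc1nccn1-c1ccc(Cl)cc1)Nc1ccccc1[N+](=O)[O-]`, limit > 321000 nM

Of the two numbers, compound 1 carries the higher one; compound 2 sits below it by a gap beyond the scatter. Compound 3 gives only a limit in this assay, (the limit of > 321000 nM in this assay, at which 1 of the 3 values shown sits), and no number.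

Compound 4 `Cc1ccc(-n2ccnc2SCC(=O)Nc2ccccc2C)cc1` has not yet been measured. It differs from compound 1 by 2-methylphenyl in place of 2-bromo-4-methylphenyl on an amide-type nitrogen. Among the measured compounds shown here, no measured pair shows this change. The expectation is a small step in this assay, towards more compound being tolerated, and not clearly beyond the scatter: a 1.4-fold higher number from compound 1 to compound 4 (0.13 log units; within the scatter). For compound 4 the estimate is 110000 nM, with a range from 40000 nM to 300000 nM.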

Compound 4, half-maximal cytotoxic concentration: 147000 nM
Compound 4: middle estimate off by 1.3-fold (0.13 log units), on the low side; low and high end bracket the measured number.
By their numbers in this assay, from the lowest: compound 2; then compounds 1 and 4 (each within the scatter of the next). At a limit, above all of these: compound 3.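

In this assay, among the compounds shown here, putting 2-methylphenyl in place of 2-bromo-4-methylphenyl on the amide-type nitrogen gives a 1.8-fold higher number from compound 1 to compound 4 (0.26 log units; within the scatter) and is the first readable step at this position. This position therefore accepts the loss of the bromine, with the accompanying change in methyl substitution, without a shift beyond the scatter. For the compounds shown here, the single step cannot separate the contribution of the bromine from that of the methyl group.

Going by these compounds, whether an amine or a carboxylic acid on this aryl ring would be tolerated as well remains open. No measurement shown bears on what lies behind this step.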